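This account rests on a few compounds, and the source may have more. Where it says the series, first, only, none or still open, it means among the compounds named here.

Compound 1 `N#CN/C(=N\CCNC(=O)c1ccccc1)NCCCOc1cccc(CN2CCCCC2)c1`: 7.82
Compound 2 `N#CN/C(=N\CCCNC(=O)c1ccccc1)NCCCOc1cccc(CN2CCCCC2)c1`: 7.14
Compound 3 `N#CN/C(=N\CCNC(=O)c1ccc(N=[N+]=[N-])cc1)NCCCCOc1cccc(CN2CCCCC2)c1`: 7.54

In a functional assay on cardiac atrium for antagonist activity at histamine H2 receptor (Cavia porcellus), tested at 0.3 uM (a higher number here means a more potent compound, by a factor of ten per unit of this negative logarithm, a lower number a less potent compound), compound 3 stands second highest of the three: compound 1 sits within the scatter of it, whereas compound 2 lies lower by more than the scatter. Within the data shown here, the only measured step, a number 0.68 log units lower from compound 1 to compound 2 (beyond the scatter), concerns the chain between the amide and the cyanoguanidine, not the aryl group of the benzamide. Compound 4 `N#CN/C(=N\CCNC(=O)c1ccc(N)c(I)c1)NCCCCOc1cccc(CN2CCCCC2)c1` differs from compound 3 by 4-amino-3-iodophenyl in place of 4-azidophenyl on a carbonyl carbon. Among the measured compounds shown here, no measured step touches that aryl group, so nothing among the three compounds anticipates this change, and the step is expected to be none beyond the scatter: a number 0.04 log units lower from compound 3 to compound 4 (within the scatter). Compound 4 is therefore estimated at 7.5, with a range from 7 to 8.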

Compound 4, negative logarithm of the antagonist equilibrium constant: 7.35
Compound 4: middle estimate off by 0.15 log units, on the high side; the measured number falls inside the stated range.
By their numbers in this assay, from the lowest: compounds 2, 4, 3 and 1 (each within the scatter of the next, the first and the last beyond it).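

The aryl group on the carbonyl carbon proved open to exchange in this assay: 4-amino-3-iodophenyl in place of 4-azidophenyl gave a number 0.19 log units lower from compound 3 to compound 4 (within the scatter), even though the entering group brings an iodine and a hydrogen-bond donor that the leaving group lacks. The earlier compounds shown here had varied only the chain, never this aryl group. Nothing available accounts for this result.

The amino group and the iodine enter together, so the compounds shown do not separate their contributions. A 4-aminophenyl or 3-iodophenyl group at this place would address that.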